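The source may hold more compounds than are shown below. What is called first, only, known or untested is meant among the compounds shown, and "the series" means these compounds.

For the measured compounds named here, in a functional assay on UO-31 cells (Homo sapiens) for antiproliferative activity, read by sulforhodamine B assay, with a stated time of 72 h (on this read-out higher numbers stand for weaker inhibition and lower numbers for stronger inhibition), three compounds have numbers so far. Compound 1 `Clc1ccc(C(/C=C/c2ccccc2)=N\Nc2nncc3ccccc23)cc1` gives 6.2 nM. Compound 2 `O=S(=O)(Nc1ccccn1)c1ccc(Nc2nncc3ccccc23)cc1` gives 44 nM, and compound 3 `COc1ccc(NC(=S)NNc2nncc3ccccc23)cc1` gives 47 nM. Compound 1 thus carries the lowest number of the three, and its gaps to compound 2 and to compound 3 both lie beyond the usual scatter, so on the numbers shown it is the strongest inhibitor of the set.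

Compound 4 `C(=C/c1ccccc1)\C(=N\Nc1nncc2ccccc12)c1ccccc1` has not yet been measured. It differs from compound 1 in one place: hydrogen in place of chloro on an aromatic carbon. Going by the values given here, no step between two measured compounds covers this change, so the measured set gives nothing to calibrate it against. The expected step is a 1.9-fold higher number from compound 1 to compound 4 (0.29 log units; within the scatter), a move toward weaker inhibition that may not clear the scatter by much. On that basis compound 4 is estimated at 12 nM in this assay. The outcome for compound 4 is expected to fall between 4 nM and 40 nM.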

Compound 4, half-maximal inhibitory concentration: 3.9 nM
Beside the measured number, compound 4's estimate is 3.1-fold (0.49 log units) above it; the measured number lies below the stated range.
By their numbers in this assay, from the lowest: compounds 4 and 1 (each within the scatter of the next); then compounds 2 and 3 (each within the scatter of the next).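

In this assay, for the compounds shown here, the change from 4-chlorophenyl to phenyl, the first one-place step, gives a 1.6-fold lower number from compound 1 to compound 4 (0.20 log units; within the scatter) and so reads as no real change at this position. A chloro on this aromatic carbon is thus not required for a number in this range, since hydrogen in its place cannot be told apart from it here. Nothing on hand gives a reason for this step.

From the compounds shown here alone, whether any group at this place would separate from chloro and hydrogen stays open; a methoxy, an amine or a carboxylic acid on the same carbon would test that. Also open, going by these compounds, is whether the other phenyl ring of compound 4 would respond to the same kind of change as little as this one did.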